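Swapping Chloro for Bromo on the Side Ring

This account rests on a few compounds, and the source may have more. Where it says the series, first, only, none or still open, it means among the compounds named here.

Measured so far:
compound 1, `Cc1ccccc1NC(=O)N[C@@H](C)c1ccccc1`: 100%
compound 2, `C[C@H](NC(=O)Nc1ccccc1F)c1ccccc1`: 98%
compound 3, `C[C@H](NC(=O)Nc1ccccc1Cl)c1ccccc1`: 99%

Three ureas built on one shared core were tested in an ADME assay on the whole organism with Oryza sativa as the target, tested at 0.1 uM; on this read-out higher numbers stand for a weaker effect at the one concentration tested and lower numbers for a stronger effect. They differ only in the small group on one aromatic ring. Compound 3 stands second highest of the three numbers: its step from compound 1 is a number 1 percentage points lower from compound 1 to compound 3 (within the scatter), and its step from compound 2 is a number 1 percentage points higher from compound 2 to compound 3 (within the scatter). All three compounds sit at the top of the scale, so in this assay none of them shows much effect at the single concentration used.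

Compound 4, `C[C@H](NC(=O)Nc1ccccc1Br)c1ccccc1`, is the next member of the series. bromo in place of chloro on an aromatic carbon Every step measured so far concerns a change at this same place: the step of a number 2 percentage points lower from compound 1 to compound 2 (within the scatter), the step of a number 1 percentage points lower from compound 1 to compound 3 (within the scatter) and the step of a number 1 percentage points higher from compound 2 to compound 3 (within the scatter). Each of these stayed within the scatter, so swapping one small group for another here has not moved the read-out. Going from chloro to bromo is expected to behave the same way, and the step is estimated at no change at the digits printed from compound 3 to compound 4 (within the scatter), with no change beyond the scatter. Compound 4 is therefore expected to give about 99%, within a range from 92% to 100%.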

Compound 4, a percentage reported as activity, at one concentration (the size of the read-out at that concentration, not a potency): 101%
The estimate for compound 4 lay 2 percentage points below the measured number, and the stated range ends below it.
By their numbers in this assay, from the lowest: compounds 2, 3, 1 and 4 (each within the scatter of the next).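

Bromo widens the set of groups tried at this place, on an aromatic carbon ortho to a large group, and in this assay the comparisons with it give a number 2 percentage points higher from compound 3 to compound 4 (within the scatter) and a number 3 percentage points higher from compound 2 to compound 4 (within the scatter) and also a number 1 percentage points higher from compound 1 to compound 4 (within the scatter) with no step standing out from the others. Methyl, fluoro, chloro and bromo can therefore not be told apart here, and the series still sits at the top of the scale, which means little effect at the one concentration tested. Nothing available explains this flat result.

It remains open whether any group at this place can bring the read-out down, as an amine, a carboxylic acid or a longer chain would put something quite different there from the single atoms and the methyl shown so far. On these data alone, it is also open whether a change elsewhere on the shared core, or a different concentration, would reveal differences that this one read-out does not separate.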